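Aryl ether versus isopropyl ether on the shared core

This account rests on a few compounds, and the source may have more. Where it says the series, first, only, none or still open, it means among the compounds named here.

Measured compounds in an in vitro assay on SH-SY5Y cells for displacement of a labelled ligand from Neuronal acetylcholine receptor; alpha3/beta4 (Homo sapiens); on this read-out lower numbers stand for stronger inhibition and higher numbers for weaker inhibition:
compound 1 `COc1cccc(Oc2cncc(C3=CC4CNCC(C3)C4)c2)c1` gives 15 nM
compound 2 `CC(C)Oc1cncc(C2=CC3CNCC(C2)C3)c1` gives 4.8 nM

Compound 2 carries the lowest of the two numbers in this assay; its nearest neighbour is compound 1, which sits at a higher number. For the measured compounds named here, the only measured step is a 3.1-fold lower number from compound 1 to compound 2 (0.49 log units; beyond the scatter), so exchanging the 3-methoxyphenyl ether for the isopropyl ether gives a modest move to a lower number.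

Compound 3 `COc1ccc(Oc2cncc(C3=CC4CNCC(C3)C4)c2)cc1` is not yet measured. It differs from compound 2 by 4-methoxyphenyl in place of isopropyl on an oxygen on an aromatic ring. Going by the values given here, this change runs in the opposite direction to the one measured step, and the group that enters is a positional isomer of the group that left in going from compound 1 to compound 2. Among the compounds with values here, the single step of a 3.1-fold lower number from compound 1 to compound 2 (0.49 log units; beyond the scatter) is therefore the only guide, and on that basis the number for compound 3 is expected to rise back toward the value of compound 1, a step of about a 2.9-fold higher number from compound 2 to compound 3 (0.46 log units; beyond the scatter). Compound 3 is estimated at 14 nM in this assay, with a range from 5 nM to 40 nM.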

Compound 3, inhibition constant: 27 nM
Compound 3: the middle estimate sits 1.9-fold (0.29 log units) below what was measured, and the stated range covers the measured number.
By their numbers in this assay, from the lowest: compound 2; then compounds 1 and 3 (each within the scatter of the next).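

In this assay, 4-methoxyphenyl in place of isopropyl on the oxygen gives a 5.6-fold higher number from compound 2 to compound 3 (0.75 log units; beyond the scatter) and confirms on a second aryl ether what compound 1 alone could only suggest: compound 2 stands apart from both methoxyphenyl ethers, with its steps to each printed as beyond the scatter. Moving the methoxy group from 3-methoxyphenyl to 4-methoxyphenyl gives a 1.8-fold higher number from compound 1 to compound 3 (0.26 log units; within the scatter) and so leaves the two aryl ethers unseparated, which means that at this position the read-out distinguishes isopropyl from methoxyphenyl but not one methoxyphenyl isomer from the other. No measurement shown accounts for the gap between the isopropyl ether and the aryl ethers.

Compound 2 is the only alkyl ether among the compounds shown, so the contrast with the aryl ethers rests on a single group. From the compounds shown here alone, whether an ethyl ether, a longer chain such as n-butyl, or an unsubstituted phenyl ring on the same oxygen would fall with compound 2 or with compound 1 and compound 3 remains open.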